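The compounds below may be only part of what the source reports. "The series", "measured", "known", "first", "only" and "open" are said of these compounds alone.

Measured compounds in an ADME assay on microsomes from liver (Mus musculus) for metabolic stability, read by LC-MS, using NADPH, with a stated time of 45 min, tested at 0.5 uM; a lower number here means slower removal, a higher number faster removal of the compound:
- compound 1, `O=C1CCCN1CCCSc1nc2cc(Cl)ccc2o1`: 51 mL/min/g
- compound 2, `CN1CCN(C(=O)CCSc2nc3cc(Cl)ccc3o2)CC1`: 41.5 mL/min/g

Compound 1 carries the highest of the two numbers; compound 2 stands a little lower, but the two values lie within the scatter of each other, so no order between them can be claimed. Within the data shown here, the two compounds share the same core and differ in more than one place, so no single step between them is available.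

Compound 3, `O=S1(=O)CCCN1CCCSc1nc2cc(Cl)ccc2o1`, is not yet measured. It differs from compound 1 in one place: a group of 7 heavy atoms (3 carbon, 1 nitrogen, 2 oxygen, 1 sulfur; one five-membered non-aromatic ring with 2 hetero atoms) in place of a group of 6 heavy atoms (4 carbon, 1 nitrogen, 1 oxygen; one five-membered non-aromatic ring with 1 hetero atom), on a saturated chain carbon, three bonds along the chain from a sulfur. Among the measured compounds shown here, nothing among the measured compounds shows what such a change does in this assay, and the two numbers available sit close together.

The step from compound 1 to compound 3 is expected to be small, a 1.3-fold lower number from compound 1 to compound 3 (0.11 log units; within the scatter), with no direction that can be claimed beyond the scatter. For compound 3 the expected value in this assay is 40 mL/min/g, with a range from 18 mL/min/g to 85 mL/min/g.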

Compound 3, intrinsic clearance in a liver preparation (reported as CLH), per the amount of preparation that the assay uses: 115 mL/min/g
Estimate against measurement, compound 3: 2.9-fold (0.46 log units) below; measured number above the stated range.
By their numbers in this assay, from the lowest: compounds 2 and 1 (each within the scatter of the next); then compound 3.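

In this assay, among these compounds, putting the ring with 2 hetero atoms and 2 double bonds outside aromatic rings in place of 2-oxopyrrolidin-1-yl, on a saturated chain carbon, three bonds along the chain from a sulfur, gives a 2.3-fold higher number from compound 1 to compound 3 (0.35 log units; beyond the scatter), a modest step and the first single-place comparison. This place is therefore not silent: with the chain and the shared core held fixed, exchanging this one group moves the number beyond the scatter, towards faster removal, which the two earlier numbers could not show. Nothing available accounts for the rise, and the step alone cannot assign it to any feature of the entering group.

Still open, as far as these compounds go, is whether the same exchange gives a step of similar size and direction on a shorter or longer chain, as the comparison rests on a single pair of compounds. Also open, from the compounds shown here alone, is how a carboxylic acid, a morpholine ring or an open-chain amide would read at this place in this assay, and so whether the higher number is particular to the entering group.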